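The source may report more compounds than this note shows. Statements on the series, on what has been measured and on what is new or still open speak of the compounds shown alone.

Compound 1, `COc1ccc(C(O)c2cn(CCCO)nn2)c(OC)c1OC`: > 100000 nM (a limit)
Compound 2, `CC1(C)OCC(Cn2cc(-c3ccc4ccccc4c3)nn2)O1`: 6600 nM

Both measured compounds were tested in a functional assay on B16 cells (Mus musculus) for cytotoxicity, read by MTT assay, with a stated time of 48 h; a higher number here means a weaker inhibitor, a lower number a stronger inhibitor. For compound 1 the value > 100000 nM is a limit of the assay and not a number. Compound 2 gives 6600 nM in this assay. Compound 1 therefore stands at the weak end of what is shown, at the limit of > 100000 nM in this assay, at which 1 of the 2 values shown sits, while compound 2 gives a measured number.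

Compound 3, `COc1ccc(C(O)c2cn(C[C@H]3COC(C)(C)O3)nn2)c(OC)c1OC`, keeps the core of compound 1 and differs from it by 2,2-dimethyl-1,3-dioxolan-4-yl in place of 2-hydroxyethyl on a saturated chain carbon bound to an aromatic nitrogen. For the measured compounds named here, no measured pair shows this change on its own; compound 2 carries the dioxolane on a different core, so its value tells only what that whole compound does and cannot be read as the size of the step.

The step is expected to move this assay toward a stronger inhibitor, by more than the scatter, though not to the level of compound 2. The expected step is an at least 2.0-fold lower number from compound 1 to compound 3 (0.30 log units; that floor lies within the scatter). For compound 3 the estimate in this assay is 50000 nM, with a range from 10000 nM to 200000 nM, and a real chance that only a limit is recorded again.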

Compound 3, half-maximal inhibitory concentration: > 100000 nM
Compound 3: only a limit was reported; the forecaster's own chance of this, stated with the estimate: 50%; middle value at least 2.0-fold (0.30 log units) from the limit.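

In this assay compound 3 gives > 100000 nM, which is a limit of the assay and not a number. Compound 1 also stands at a limit, so no step between compound 1 and compound 3 can be read: the limit of > 100000 nM in this assay, at which 2 of the 3 values shown sit.

The compounds shown leave open whether 2,2-dimethyl-1,3-dioxolan-4-yl in place of 2-hydroxyethyl changes the value on the shared core at all.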